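Changing the group on the ring amine nitrogen

The source may hold more compounds than are shown below. What is called first, only, known or untested is meant among the compounds shown, and "the series" means these compounds.

Compound 1 `Nc1scc(CN2CCN(c3ccc(Cl)c(C(F)(F)F)c3)CC2)c1C(=O)c1ccc(Cl)cc1` stands highest of the three numbers shown: in a functional assay on CHO cells with adenosine receptor A1 (Homo sapiens) as the target, read by cAMP accumulation and immunoassay, with a stated time of 6 min, tested at 0.1 uM (on this read-out lower numbers stand for a stronger effect and higher numbers for a weaker effect at the one concentration tested), compound 1 gives -12%. Compound 2 `Nc1scc(CN2CCN(c3ccc(OC(F)(F)F)cc3)CC2)c1C(=O)c1ccc(Cl)cc1` gives -13%, and compound 3 `Nc1scc(CN2CCN(c3cc(F)ccc3F)CC2)c1C(=O)c1ccc(Cl)cc1` gives -13%. The steps are small: a number 1 percentage points lower from compound 1 to compound 2 (within the scatter), a number 1 percentage points lower from compound 1 to compound 3 (within the scatter), and no change at the digits printed from compound 2 to compound 3 (within the scatter). Compound 4 `Nc1scc(CN2CCN(c3cc(Cl)ccc3Cl)CC2)c1C(=O)c1ccc(Cl)cc1` differs from compound 1 in one place only: 2,5-dichlorophenyl in place of 4-chloro-3-(trifluoromethyl)phenyl on an amine nitrogen in a ring. All three measured steps swap one aromatic group for another on the same amine nitrogen in a ring, so each bears on this change, and each stayed within the scatter. No step beyond the scatter is therefore expected in this assay. Compound 4 is expected to give -12%, with a range from -24% to 0%, which means an expected no change at the digits printed from compound 1 to compound 4 (within the scatter).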

Compound 4, a percentage reported as activity, at one concentration (the size of the read-out at that concentration, not a potency): -6.2%
The estimate for compound 4 lay 5.8 percentage points below the measured number; the measured number falls inside the stated range.
By their numbers in this assay, from the lowest: compounds 2, 3, 1 and 4 (each within the scatter of the next).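

In this assay the steps of a number 5.8 percentage points higher from compound 1 to compound 4 (within the scatter) and a number 6.8 percentage points higher from compound 3 to compound 4 (within the scatter) and a number 6.8 percentage points higher from compound 2 to compound 4 (within the scatter) all stay within the scatter, so 2,5-dichlorophenyl reads the same as the three earlier aromatic groups on this amine nitrogen. The step from compound 3 to compound 4 also adds a direct swap of 2,5-difluorophenyl for 2,5-dichlorophenyl, and it too gives no step beyond the scatter. Nothing shown offers a reason for these numbers. Open, going by these compounds, is whether a benzyl group, an acetyl group or a phenyl ring carrying a carboxylic acid on this nitrogen would step beyond the scatter.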